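Thiophene exchange on the shared core

The compounds below may be only part of what the source reports. "The series", "measured", "known", "first", "only" and "open" are said of these compounds alone.

Compound 1 (`Cc1cc(C(=O)/C=C/c2cc3cccc(C)c3nc2Cl)c(C)s1`) offers no number to start from: in a functional assay on HUVEC cells (Homo sapiens), read by BrdU incorporation, with a stated time of 72 h (a lower number here means a stronger inhibitor, a higher number a weaker inhibitor), compound 1 stands as "not determined" (no result reported). The only figure so far comes from compound 2 (`Cc1ccc2nc(Cl)c(/C=C/C(=O)c3ccc(Cl)s3)cc2c1`), at 59.4 nM. Compound 3 (`Cc1cccc2cc(/C=C/C(=O)c3ccc(I)s3)c(Cl)nc12`) carries 5-iodothiophen-2-yl in place of 2,5-dimethylthiophen-3-yl on a carbonyl carbon, that is, 5-iodothiophen-2-yl in place of 2,5-dimethylthiophen-3-yl on a carbonyl carbon. Among the compounds with values here, with no measured starting point, no step from compound 1 can be sized, so the expectation is a result within the usual scatter of compound 2 at 59.4 nM, in neither direction. The estimated value in this assay for compound 3 is 60 nM, with an expected range of 15 nM to 250 nM.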

Compound 3, half-maximal inhibitory concentration: 284 nM
Beside the measured number, compound 3's estimate is 4.7-fold (0.68 log units) below it, outside the stated range (above it).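

Within the data shown here, no step from compound 1 to compound 3 can be read in this assay. On these data alone, what the exchange of 2,5-dimethylthiophen-3-yl for 5-iodothiophen-2-yl does to potency stays open. No evidence bearing on this result is at hand.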